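Swapping the aryl group on a butyl-bearing pyridine amide

The compounds below may be only part of what the source reports. "The series", "measured", "known", "first", "only" and "open" are said of these compounds alone.

Measured so far:
- compound 1 `CCOc1cc(C(=O)Nc2nn[nH]n2)nc(-c2ccc(N)cc2)c1`: 52% in a functional assay on the whole organism with Rattus norvegicus as the target, at a dose of 1 mg/kg by the oral route; on this read-out higher numbers stand for a stronger effect at the one dose given and lower numbers for a weaker effect
- compound 2 `Nc1ccc(-c2cccc(C(=O)Nc3nn[nH]n3)n2)cc1`: 62% in this assay
- compound 3 `CCCCc1cc(C(=O)Nc2nn[nH]n2)nc(-c2cccc(C)c2)c1`: 36% in this assay

Compound 3 has the lowest of the three numbers. Compound 1 stands nearest to it and is higher beyond the scatter, and compound 2 is further off, also beyond the scatter. For the measured compounds named here, the only single-point step among the measured compounds, a number 10 percentage points higher from compound 1 to compound 2 (within the scatter), concerns a different position and lies within the scatter, so it does not bear on the change now at hand.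

Compound 4 `CCCCc1cc(C(=O)Nc2nn[nH]n2)nc(-c2ccc(N)cc2)c1` arises from compound 3 by one change: 4-aminophenyl in place of 3-methylphenyl on an aromatic carbon. Going by the values given here, no measured pair isolates this change. Compounds 1 and 2 both carry 4-aminophenyl and both sit above compound 3, but each also differs from compound 3 elsewhere, so their values only hint at the direction. An upward step is therefore expected, but with wide uncertainty. For compound 4 the expected change is a number 14 percentage points higher from compound 3 to compound 4 (beyond the scatter), and the estimated read-out for compound 4 is 50%, with a range from 30% to 70% in this assay.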

Compound 4, a percentage reported as inhibition, in the whole organism at one dose (the size of the read-out at that dose, not a potency): 81%
Estimate against measurement, compound 4: 31 percentage points below; measured number outside the range, above it.
By their numbers in this assay, from the lowest: compound 3; then compounds 1 and 2 (each within the scatter of the next); then compound 4.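

With butyl held constant, the swap from 3-methylphenyl to 4-aminophenyl gives a number 45 percentage points higher from compound 3 to compound 4 (beyond the scatter) in this assay, so this aryl change now has a measured size of its own, and it is large. With 4-aminophenyl held constant, the other position can also be read: butyl in place of hydrogen gives a number 19 percentage points higher from compound 2 to compound 4 (beyond the scatter), and butyl in place of ethoxy gives a number 29 percentage points higher from compound 1 to compound 4 (beyond the scatter), a modest gain in both cases. No data at hand explain these steps.

The aryl swap alters both the substituent and where it sits on the phenyl ring, so the compounds shown cannot separate those two changes. Also open, going by these compounds, is how an unsubstituted phenyl, a hydroxyl in place of the amine, or a chain longer than butyl would read at this one dose.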